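The source may report more compounds than this note shows. Statements on the series, on what has been measured and on what is new or still open speak of the compounds shown alone.

Compound 1 `COC(=O)c1ccc2c(ccn2-c2ccc(NC(=O)Nc3ccc(Cl)c(Cl)c3)cc2)n1`: in an ADME assay on HS27 cells (Homo sapiens) for cytotoxicity, read by MTT assay (a higher number here means a weaker inhibitor, a lower number a stronger inhibitor), compound 1 gives 2800 nM. Compound 2 `COC(=O)c1ccc2c(ccn2-c2cccc(NC(=O)Nc3cccc(C(F)(F)F)c3)c2)n1`: in this assay compound 2 reaches only the limit of the assay, > 10000 nM. Compound 3 `COC(=O)c1ccc2c(ccn2-c2cccc(NC(=O)c3cccc(C(F)(F)F)c3)c2)n1`: in this assay compound 3 likewise sits at a limit, > 10000 nM.

For the measured compounds named here, compound 1 thus holds the only number in the set; the other two values are limits, and a step that the two limits leave unreadable from compound 2 to compound 3 cannot be sized because of the limit of > 10000 nM in this assay, at which 2 of the 3 values shown sit. Compound 4 `NC(=O)c1ccc2c(ccn2-c2ccc(NC(=O)Nc3ccc(Cl)c(Cl)c3)cc2)n1` differs from compound 1 by amino in place of methoxy on a carbonyl carbon. Going by the values given here, no measured step touches this position, and the one step recorded is unreadable, so there is nothing to carry over. The change is expected to leave the value within scatter, as a 1.4-fold higher number from compound 1 to compound 4 (0.15 log units; within the scatter). Compound 4 is therefore estimated at 4000 nM, ranging from 1500 nM to 12000 nM.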

Compound 4, half-maximal inhibitory concentration: 6600 nM
Estimate against measurement, compound 4: 1.7-fold (0.22 log units) below; measured number inside the range.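

Methoxycarbonyl to carbamoyl is the first readable change in the series, and in this assay it gives a 2.4-fold higher number from compound 1 to compound 4 (0.37 log units; beyond the scatter). Amino in place of methoxy on a carbonyl carbon therefore shifts the read-out modestly towards a weaker inhibitor, and compound 4 still gives a measured number rather than a limit. This rests on a single pair and sets no trend for the position.

On these data alone, whether a carboxylic acid or a methylamide on this carbonyl carbon would shift the number further remains open. Compound 2 and compound 3 add nothing on this position, and their step cannot be read because of the limit: the limit of > 10000 nM in this assay, at which 2 of the 4 values shown sit.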